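From open chain to ring in compound 4

This account rests on a few compounds, and the source may have more. Where it says the series, first, only, none or still open, it means among the compounds named here.

Values in a functional assay on HT-29 cells (Homo sapiens) for inhibition, read by sulforhodamine B assay, with a stated time of 48 h (a lower number here means a stronger inhibitor, a higher number a weaker inhibitor), so far:
- compound 1 `CCNC(=O)Nc1ccc(/C=C/c2cccc(Cl)c2)cc1` gives > 20000 nM as a limit
- compound 2 `CCNC(=O)Nc1ccc(/C=C\c2cccc(Cl)c2)cc1` gives 26000 nM
- compound 3 `CCNC(=O)Nc1ccc(/C=C/c2cc(OC)c(OC)c(OC)c2)cc1` gives 12000 nM

Of the two real numbers, compound 2 stands highest at 26000 nM and is the weaker inhibitor of the pair. Compound 4 `O=C1NCCN1c1ccc(/C=C\c2cccc(Cl)c2)cc1` carries 2-oxoimidazolidin-1-yl in place of (ethylcarbamoyl)amino on an aromatic carbon and otherwise matches compound 2. Going by the values given here, the only measured step (a step that the limit leaves unreadable from compound 1 to compound 2) reflects the fact that compounds 1 and 2 differ only in the configuration as drawn and leaves this group untouched. Its size is unreadable (because of the limit of > 20000 nM in this assay, at which 1 of the 3 values shown sits). Starting from compound 2 at 26000 nM with no measured guide, no step beyond the scatter is expected in this assay and neither direction is favoured. The expected change is a 1.1-fold lower number from compound 2 to compound 4 (0.03 log units; within the scatter) and it remains an estimate. Compound 4 is estimated at 24000 nM with an expected range from 9000 nM to 60000 nM around that figure.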

Compound 4, half-maximal inhibitory concentration: 25 nM
Beside the measured number, compound 4's estimate is 960-fold (2.98 log units) above it; measured number below the stated range.
By their numbers in this assay, from the lowest: compound 4; then compound 3; then compound 2.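

The earlier compounds shown here all carried the open (ethylcarbamoyl)amino chain, so this place on the aromatic ring had not yet been varied. In this assay, 2-oxoimidazolidin-1-yl at this place gives a 1000-fold lower number from compound 2 to compound 4 (3.02 log units; beyond the scatter), even though the heavy atoms entering match those leaving, now closed into a five-membered non-aromatic ring with 1 hydrogen-bond donor instead of 2. Nothing measured here bears on why the step is so large.

Going by these compounds, whether the ring brings the same gain with the E double bond of compound 1 stays open. So does whether a six-membered urea ring or a plain amine at this place would keep it.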